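The compounds below may be only part of what the source reports. "The series", "measured", "known", "first", "only" and "open" are said of these compounds alone.

In a functional assay, read by spectrophotometry, with a stated time of 3 min (on this read-out lower numbers stand for stronger inhibition and higher numbers for weaker inhibition), three compounds sharing one core have been measured. Compound 1 `Cc1ccc2[nH]c(=O)c(/C=N/c3ccccc3O)cc2c1` gives 8240 nM. Compound 2 `Cc1ccc2[nH]c(=O)c(/C=N/Nc3ccccc3)cc2c1` gives 8470 nM, and compound 3 `Cc1ccc2[nH]c(=O)c(/C=N/NC(=O)CS(N)(=O)=O)cc2c1` gives 9170 nM. Between them, the step of a 1.0-fold higher number from compound 1 to compound 2 (0.01 log units; within the scatter) and the step of a 1.1-fold higher number from compound 2 to compound 3 (0.03 log units; within the scatter) both stay inside the scatter, so the three values cannot be placed in any order. Compound 2 sits among them with nothing separating it from compound 1 or from compound 3 beyond the noise of the read-out.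

Compound 4 `O=c1[nH]c2ccccc2cc1/C=N/Nc1ccccc1` has not yet been measured. It differs from compound 2 in one place: hydrogen in place of methyl on an aromatic carbon. Neither of the two measured steps touches this position; both concern the group carried on the double-bonded nitrogen, and the methyl on the aromatic carbon is present in all three measured compounds. Among the measured compounds shown here, there is therefore no step bearing directly on this change, and the measured steps, all inside the scatter, give no sign that small changes on this core move the read-out.

The step of a 1.0-fold higher number from compound 2 to compound 4 (0.00 log units; within the scatter) is therefore expected to lie within the scatter. Compound 4 is estimated at 8500 nM, with a range from 4000 nM to 18000 nM.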

Compound 4, half-maximal inhibitory concentration: 11800 nM
Beside the measured number, compound 4's estimate is 1.4-fold (0.14 log units) below it; low and high end bracket the measured number.
By their numbers in this assay, from the lowest: compounds 1, 2, 3 and 4 (each within the scatter of the next).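

In this assay, among the compounds shown here, the step of a 1.4-fold higher number from compound 2 to compound 4 (0.14 log units; within the scatter) is the first direct reading at this aromatic carbon, and it stays within the scatter, so hydrogen in place of methyl here gives no separation that the read-out can resolve. The earlier compounds shown here could not show this, since all three carry the methyl and their steps concern only the group on the nitrogen. No measurement is available that would account for the size of this step or tie it to any property of either group.

The compounds shown carry only methyl or hydrogen at this place, so it remains open whether a larger or different group on this aromatic carbon, such as a methoxy group, a chlorine atom, an amine or a carboxylic acid, would produce a step beyond the scatter. Going by these compounds, it also remains open whether the exchange of methyl for hydrogen would read the same with the 2-hydroxyphenyl group of compound 1 or the (sulfamoylmethyl)carbonyl group of compound 3 in place of the anilino group.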